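Aryl piperazine amides of the oxazole core: notes on compound 3

The source may hold more compounds than are shown below. What is called first, only, known or untested is meant among the compounds shown, and "the series" means these compounds.

The series shares the core of compound 1 `Cc1nc(-c2ccccc2)c(C(=O)N2CCN(c3c(C)cccc3C)CC2)o1`, in which an amide links a piperazine to an oxazole; the variable part is the aryl group on the amine nitrogen in the ring. In a functional assay on HL-60 cells (Homo sapiens) for inhibition, read by MTT assay, with a stated time of 72 h (on this read-out higher numbers stand for weaker inhibition and lower numbers for stronger inhibition), compound 1 gives 146 nM. Compound 2 `COc1cccc(N2CCN(C(=O)c3oc(C)nc3-c3ccc(F)cc3)CC2)c1`, which carries a 3-methoxyphenyl at that position and a fluorine on the pendant phenyl, gives in this assay 112 nM. The two numbers lie within the usual scatter of each other, so compound 1 cannot be set apart from compound 2 on this read-out; on the numbers shown it simply stands alongside it.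

Compound 3 `C=C(C)c1ccc(N2CCN(C(=O)c3oc(C)nc3-c3ccccc3)CC2)cc1` is not yet measured. It differs from compound 1 in one place: 4-(1-methylethenyl)phenyl in place of 2,6-dimethylphenyl on an amine nitrogen in a ring.

Going by the values given here, no step between measured compounds is at hand for this kind of change. Because compound 2 with a differently substituted aryl still gives 112 nM, the aryl on the ring nitrogen appears tolerant of variation among the measured compounds, and the step from compound 1 to compound 3 in this assay is expected to be a 1.0-fold lower number from compound 1 to compound 3 (0.02 log units; within the scatter), not beyond the scatter in either direction. Compound 3 is therefore estimated at 140 nM in this assay, with a plausible range from 50 nM to 400 nM.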

Compound 3, half-maximal inhibitory concentration: "not active" (no number reported)
No number was reported for compound 3; no gap can be computed for the estimate.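

Going by these compounds alone, compound 3 is reported as not active in this assay without a number, and no step from compound 1 to compound 3 can be read. Nothing at hand bears on the reason for this result. The compounds shown leave open how large the gap between compound 1 and compound 3 is on this read-out.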